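The compounds below may be only part of what the source reports. "The series", "measured", "known", "first", "only" and "open" are said of these compounds alone.

Measured compounds in an assay on cells with Cystic fibrosis transmembrane conductance regulator variant F508del (Homo sapiens) as the target, read by fluorescence, with stated times of 24 h and 30 min; on this read-out higher numbers stand for an effect only at larger amounts of compound and lower numbers for an effect already at smaller amounts: compound 1 `CN1CCN(CCCNc2nc(-c3cccnc3)nc3c2CN(Cc2ccccc2)CC3)CC1` gives 100000 nM; compound 2 `Cc1cc(C)c2cc(C#N)c(NCCNC(=O)c3ccccc3)nc2c1` gives 100000 nM; compound 3 `COc1ccc(NC(=O)n2nc(-c3sc(NC(=O)C(C)(C)C)nc3C)cc2Cc2cc(Cl)ccc2OC)cc1` gives 1000 nM.

Compound 1 stands level with compound 2 at the digits shown, the two together holding the highest number of the three; compound 3 lies far lower, well beyond the scatter. Compound 4 `CN(C)CCN1CCN(c2nc(-c3cccnc3)nc3c2CN(Cc2ccccc2)CC3)CC1` holds the same atoms as compound 1, joined differently: 4-(2-(dimethylamino)ethyl)piperazin-1-yl in place of (3-(4-methylpiperazin-1-yl)propyl)amino on an aromatic carbon. Among the compounds with values here, no pair of measured compounds differing in one place has been recorded, so no step size is known for a change of this kind. Within the data shown here, the only anchor is compound 1 at 100000 nM in this assay. The rearrangement is expected to leave the number where it is, with no step beyond the scatter: no change at the digits printed from compound 1 to compound 4 (within the scatter) is the expected step. Compound 4 is therefore estimated at 100000 nM, ranging from 30000 nM to 100000 nM.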

Compound 4, half-maximal effective concentration: 100000 nM
Beside the measured number, compound 4's estimate shows no gap at the digits printed, within the range that was stated.
By their numbers in this assay, from the lowest: compound 3; then compounds 1, 2 and 4 (each within the scatter of the next).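

At this aromatic carbon next to the ring nitrogen, 4-(2-(dimethylamino)ethyl)piperazin-1-yl in place of (3-(4-methylpiperazin-1-yl)propyl)amino gives no change at the digits printed from compound 1 to compound 4 (within the scatter) in this assay. This first step read at the position shows that the number holds when the same atoms are rejoined and the hydrogen-bond donor of the side chain is gone. No outside evidence bears on this result.

Open, going by these compounds, is whether a morpholine, a primary amine or a carboxylic acid at this carbon would give a lower number. Also open, on these data alone, is what a group other than pyridin-3-yl would do on the shared core.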